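Cytotoxicity series on macrophage cells: thiocarbamate analogues

This account rests on a few compounds, and the source may have more. Where it says the series, first, only, none or still open, it means among the compounds named here.

Measured compounds:
- compound 1, `CC(C)(Oc1ccc(Cl)cc1)C(=O)NCCOC(=S)Nc1ccc([N+](=O)[O-])cc1Cl`: > 800000 nM
- compound 2, `Cc1cnc(C(=O)Oc2ccc(C(N)=S)cc2)c[n+]1[O-]`: > 800000 nM
- compound 3, `O=C(NCCOC(=S)Nc1ccc(F)cc1)c1cccnc1`: > 800000 nM

In an ADME assay on RAW264.7 cells (Mus musculus) for cytotoxicity, read by MTT assay, with a stated time of 48 h (a lower number here means a stronger inhibitor, a higher number a weaker inhibitor), compound 1 shows only a limit, > 800000 nM, and no number. The value given for compound 2 in this assay is likewise a limit, > 800000 nM. For compound 3 the result in this assay is also a limit, > 800000 nM. All three results therefore sit at the limit of > 800000 nM in this assay, at which 3 of the 3 values shown sit, so compound 1 cannot be placed above or below any other compound on these numbers; nothing in the series has yet given a measurable value.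

The next compound, compound 4, `CC(C)(Oc1ccc(Cl)cc1)C(=O)NCCOC(=S)Nc1ccccc1`, is not yet measured. It differs from compound 1 in one place: phenyl in place of 2-chloro-4-nitrophenyl on an amide-type nitrogen.

Among the compounds with values here, no measured step between compounds exists here, so the size of the change can only be guessed. With every value shown sitting at the limit, the expectation is that compound 4 behaves no differently beyond the scatter; the step from compound 1 to compound 4 is expected to be a step that the limit leaves unreadable from compound 1 to compound 4. In this assay compound 4 is estimated at 1000000 nM, within a range of 300000 nM to 3000000 nM, most likely again reported only as a limit.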

Compound 4, half-maximal inhibitory concentration: > 800000 nM
Compound 4 gave a limit, no number; the forecaster's own chance of this, stated with the estimate: 85%; the middle value lies beyond the limit too.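

Compound 1 and compound 4 both give only a limit, so no step between them can be read, because neither result is a number: the limit of > 800000 nM in this assay, at which 4 of the 4 values shown sit.

The compounds shown leave open whether phenyl in place of 2-chloro-4-nitrophenyl changes anything in this assay, and which structures would give a measurable value there.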